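Swapping the sulfonyl for a thiazolylcarbonyl on the ring nitrogen

This account rests on a few compounds, and the source may have more. Where it says the series, first, only, none or still open, it means among the compounds named here.

Measured compounds:
compound 1, `CCCCNc1nc(N)nc2c1CN(S(C)(=O)=O)CC2`, 9.9 uM;
compound 2, `CCCCNc1nc(N)nc2c1CCN(S(C)(=O)=O)C2`, 0.8 uM;
compound 3, `CCCCNc1nc(N)nc2c1CN(Cc1c[nH]c3ccccc13)CC2`, 0.22 uM.

In an assay on HEK293 cells for agonist activity at Toll-like receptor 8 (Homo sapiens), read by a luciferase reporter, with a stated time of 6 h (a lower number here means that less compound is needed, a higher number that more compound is needed for the effect), compound 1 gives 9.9 uM, the highest of the three numbers. Compound 2 stands a good deal lower, a gap that lies beyond the scatter, and compound 3, which carries a different group on the amine nitrogen in the ring of the shared core, stands lower still, again beyond the scatter.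

Compound 4, `CCCCNc1nc(N)nc2c1CN(C(=O)c1cscn1)CC2`, has not yet been measured in this assay. It differs from compound 1 in one place: (1,3-thiazol-4-yl)carbonyl in place of methylsulfonyl on an amine nitrogen in a ring. Among the compounds with values here, no measured pair shows this exact change, so its size can only be guessed from what the three measured compounds show. Compound 3 indicates that replacing the methylsulfonyl on that ring nitrogen by a group holding an aromatic ring can go with a far lower number, and compound 4 also brings an aromatic ring to that position, though joined through a carbonyl rather than directly.

Compound 4 is therefore expected to give 1.5 uM, with a range from 0.3 uM to 8 uM. The step of a 6.6-fold lower number from compound 1 to compound 4 (0.82 log units; beyond the scatter) is expected to be downward and beyond the scatter.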

Compound 4, minimum effective concentration: 0.5 uM
Beside the measured number, compound 4's estimate is 3.0-fold (0.48 log units) above it, and the stated range covers the measured number.
By their numbers in this assay, from the lowest: compound 3; then compounds 4 and 2 (each within the scatter of the next); then compound 1.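

In this assay, within the data shown here, the exchange of methylsulfonyl for (1,3-thiazol-4-yl)carbonyl on an amine nitrogen in a ring gives a 20-fold lower number from compound 1 to compound 4 (1.30 log units; beyond the scatter) as a large step, the first single change at this position whose size can be read directly. Among these compounds, it shows that the high number of compound 1 is not fixed by the shared core, since the number falls far beyond the scatter with only this group changed. It also shows that a group joined to this nitrogen through a carbonyl can go with a low number, as compound 4 gives 0.5 uM in this assay while the group of compound 3 holds an aromatic ring but no carbonyl. Nothing given here explains the step.

On these data alone, the carbonyl and the five-membered aromatic ring enter together in this one change, so their separate shares in the step remain open. An acetyl group or a benzoyl group on the same nitrogen would bear on that question, and a phenylsulfonyl group would show whether an aromatic ring goes with a low number while the sulfonyl stays.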